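This account rests on a few compounds, and the source may have more. Where it says the series, first, only, none or still open, it means among the compounds named here.

Measured compounds:
compound 1 `O=C(C1CCC1)N1CC2CC(C1)N2`: 100%
compound 2 `O=C(CC1C=CCC1)N1CC2CC(C1)N2`: 89%

In an assay on SH-EP1 cells for agonist activity at Neuronal acetylcholine receptor; alpha4/beta2 (Homo sapiens), read by FLIPR and calcium flux (on this read-out lower numbers stand for smaller maximal responses and higher numbers for larger maximal responses), compound 1 gives the higher of the two numbers; compound 2 sits lower by an amount beyond the usual scatter. Compound 3 `C[C@H]1C[C@H]1C(=O)N1CC2CC(C1)N2` has not yet been measured. It differs from compound 1 by 2-methylcyclopropyl in place of cyclobutyl on a carbonyl carbon. Going by the values given here, no step between measured compounds covers this change; given the same atoms joined differently, a small downward step or none beyond the scatter is expected in this assay. For compound 3 the estimate is 92%, with a range of 75% to 110%. The step of a number 8 percentage points lower from compound 1 to compound 3 (within the scatter) is the expected one.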

Compound 3, largest response reached (Emax), in percent of the reference or control that the assay uses: 87%
Compound 3: the middle estimate sits 5 percentage points above what was measured; measured number inside the range.
By their numbers in this assay, from the lowest: compounds 3 and 2 (each within the scatter of the next); then compound 1.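

On the carbonyl carbon, in this assay, 2-methylcyclopropyl in place of cyclobutyl gives a number 13 percentage points lower from compound 1 to compound 3 (beyond the scatter), a modest change. The two groups have the same count of four carbon atoms, so at this position the maximal response depends on how those atoms are joined, not only on how many there are. Nothing available explains this step.

On these data alone, it remains open how the other stereoisomers of 2-methylcyclopropyl would behave. Also open, as far as these compounds go, is whether plain cyclopropyl, a longer alkyl chain or an amine-bearing group at this position would match compound 1.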